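The source may report more compounds than this note shows. Statements on the series, on what has been measured and on what is new or still open speak of the compounds shown alone.

Measured:
Compound 1 `Cc1cc(O)cc(-c2nn(CC#N)cc2-c2ccnc(-c3ccc(Oc4ccccc4)cc3)c2)c1`: in a functional assay on HCT-15 cells (Homo sapiens) for inhibition, read by sulforhodamine B assay, with a stated time of 48 h (a lower number here means a stronger inhibitor of growth, a higher number a weaker inhibitor of growth), compound 1 gives 2140 nM.
Compound 2 `COc1cc(C)cc(-c2nn(CC#N)cc2-c2ccnc(-c3ccc(N(C)C)cc3)c2)c1`: in this assay compound 2 gives 350 nM.

Compound 2 holds the lowest of the two numbers; compound 1 sits well above it, beyond the scatter. Compound 3 `Cc1cc(O)cc(-c2nn(CC#N)cc2-c2ccnc(-c3ccc(N(C)C)cc3)c2)c1` differs from compound 2 by hydrogen in place of methyl on an oxygen on an aromatic ring. Going by the values given here, no measured pair isolates this change; compounds 1 and 2 differ in two places, so their gap does not speak to the oxygen substituent alone. A small step, or none beyond the scatter, is expected. The step from compound 2 to compound 3 is estimated as a 1.4-fold higher number from compound 2 to compound 3 (0.15 log units; within the scatter). Compound 3 is expected to give 500 nM, between 200 nM and 1500 nM.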

Compound 3, concentration for 50% growth inhibition: 3360 nM
For compound 3 the middle estimate is 6.7-fold (0.83 log units) below the measured one, and the stated range ends below it.
By their numbers in this assay, from the lowest: compound 2; then compounds 1 and 3 (each within the scatter of the next).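

In this assay the oxygen substituent matters: methoxy to hydroxy gives a 9.6-fold higher number from compound 2 to compound 3 (0.98 log units; beyond the scatter), so this position is sensitive to the loss of one methyl. With hydroxy held, dimethylamino in place of phenoxy gives a 1.6-fold higher number from compound 1 to compound 3 (0.20 log units; within the scatter), so that swap does not separate these two hydroxy compounds. Nothing measured here accounts for the methoxy to hydroxy step.

On these data alone, whether methoxy keeps its advantage over hydroxy when phenoxy replaces dimethylamino remains open. An ethoxy group or an amine at this place would show whether the step is specific to methoxy.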